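This account rests on a few compounds, and the source may have more. Where it says the series, first, only, none or still open, it means among the compounds named here.

Measured compounds:
`Cc1ccc(C(=O)/C=C/c2ccc3c(c2)B(O)OC3)cc1` compound 1; in an ADME assay on L929 cells (Mus musculus) for cytotoxicity, read by resazurin assay, with a stated time of 72 h (on this read-out lower numbers stand for stronger inhibition and higher numbers for weaker inhibition), compound 1 gives > 10 ug/mL, a limit of the assay and not a number.
`O=C(/C=C/c1ccc2c(c1)B(O)OC2)c1ccccc1O` compound 2; in this assay compound 2 gives > 10 ug/mL, also a limit.
`O=C(/C=C/c1ccc2c(c1)B(O)OC2)c1ccccn1` compound 3; in this assay compound 3 gives > 10 ug/mL, also a limit.

Compound 1 stands only at a limit, as do the two further values. The steps a step that the two limits leave unreadable from compound 1 to compound 2, a step that the two limits leave unreadable from compound 1 to compound 3 and a step that the two limits leave unreadable from compound 2 to compound 3 cannot be read, because all three values sit at the limit of > 10 ug/mL in this assay, at which 3 of the 3 values shown sit. Compound 4, `O=C(/C=C/c1ccc2c(c1)B(O)OC2)c1ccc(-c2ccccc2)cc1`, differs from compound 1 by phenyl in place of methyl on an aromatic carbon. Among the compounds with values here, no measured step carries a readable size onto this change, so no step beyond the scatter can be foreseen in this assay; the expectation is that compound 4 also ends at the limit. Compound 4 is expected near 12 ug/mL, within 4 ug/mL to 40 ug/mL. The estimated step is a step that the limit leaves unreadable from compound 1 to compound 4.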

Compound 4, half-maximal inhibitory concentration: > 10 ug/mL
Compound 4 was reported as a limit (the forecaster's own chance of this, stated with the estimate: 70%); the middle value is on the limit's open side.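

Compound 1 and compound 4 both stand at a limit, not a number, in this assay, so no step between them can be read: the limit of > 10 ug/mL in this assay, at which 4 of the 4 values shown sit.

The compounds shown leave open whether any change on the shared core gives a readable value in this assay.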